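A few compounds are considered here, and "the series" means these few. Any claim that something is new, unique, unknown or untested is made for them only; others in the source may bear on it.

Measured compounds in an assay on COS-7 cells for displacement of a labelled ligand from 5-hydroxytryptamine receptor 4 (Homo sapiens), read by scintillation counting, with a stated time of 30 min; on this read-out lower numbers stand for stronger inhibition and higher numbers for weaker inhibition:
- compound 1, `CCOC(=O)N1CCC(CN2CC[C@H](NC(=O)c3cc(Cl)c(N)cc3OC)[C@H](OC)C2)CC1`, 377 nM
- compound 2, `COc1cc(N)c(Cl)cc1C(=O)N[C@H]1CCN(CCCn2cccc2)C[C@H]1OC`, 648 nM
- compound 3, `CCC(=S)N1CCC(CN2CC[C@H](NC(=O)c3cc(Cl)c(N)cc3OC)[C@H](OC)C2)CC1`, 593 nM

All three share the core of compound 1 and differ only in the group on the saturated chain carbon bound to the amine nitrogen in the ring. Compound 3 gives the second highest of the three numbers in this assay; its nearest neighbour is compound 2, a 1.1-fold lower number from compound 2 to compound 3 (0.04 log units; within the scatter), and its furthest is compound 1, a 1.6-fold higher number from compound 1 to compound 3 (0.20 log units; within the scatter). Neither gap leaves the scatter, so the three compounds are not ordered by these data.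

Compound 4, `CCC(=O)N1CCC(CCN2CC[C@H](NC(=O)c3cc(Cl)c(N)cc3OC)[C@H](OC)C2)CC1`, is the next step from compound 3: a group of 11 heavy atoms (9 carbon, 1 nitrogen, 1 oxygen; one six-membered non-aromatic ring with 1 hetero atom) in place of a group of 10 heavy atoms (8 carbon, 1 nitrogen, 1 sulfur; one six-membered non-aromatic ring with 1 hetero atom), on a saturated chain carbon bound to an amine nitrogen in a ring. The step from compound 1 to compound 3 is the one that bears most directly on this change, since it also exchanges an oxygen-bearing group for a sulfur-bearing one on the amine nitrogen in the ring, and it stayed within the scatter; the step from compound 1 to compound 2, which replaces the whole group, was likewise within the scatter. For the measured compounds named here, no measured pair speaks to the lengthening of the chain by itself. Taken together, a step of a 1.3-fold lower number from compound 3 to compound 4 (0.12 log units; within the scatter) is expected, that is, nothing beyond the scatter. Compound 4 is therefore estimated at 450 nM in this assay, with a range of 200 nM to 1000 nM.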

Compound 4, half-maximal inhibitory concentration: 805 nM
Beside the measured number, compound 4's estimate is 1.8-fold (0.25 log units) below it, and the stated range covers the measured number.
By their numbers in this assay, from the lowest: compounds 1, 3, 2 and 4 (each within the scatter of the next, the first and the last beyond it).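

In this assay, for the compounds shown here, the (1-propanoylpiperidin-4-yl)methyl group gives the first step to leave the scatter, a 2.1-fold higher number from compound 1 to compound 4 (0.33 log units; beyond the scatter), although it is only a modest one, so replacing 1-(ethoxycarbonyl)piperidin-4-yl at this place can separate two compounds. The separation holds for this pair alone: a 1.4-fold higher number from compound 3 to compound 4 (0.13 log units; within the scatter) and a 1.2-fold higher number from compound 2 to compound 4 (0.09 log units; within the scatter) both stay within the scatter, so compound 2, compound 3 and compound 4 remain unordered, and compound 1 is not set apart from compound 2 or compound 3. No available evidence bears on this result.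

The step to compound 4 joins a lengthened chain with a propanoyl group in place of ethoxycarbonyl, and no pair shown separates the two changes, so the share of each remains open. Also open, going by these compounds, is whether a still longer chain, or an amine or a carboxylic acid in place of the propanoyl group, would give a step beyond the scatter against compound 2 or compound 3.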